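Methyl on the piperidin-1-yl ring: compound 2 to compound 3

The source may hold more compounds than are shown below. What is called first, only, known or untested is meant among the compounds shown, and "the series" means these compounds.

Two compounds of the series have numbers in a functional assay on HT-29 cells (Homo sapiens) for cytotoxicity, read by MTT assay, with a stated time of 72 h; on this read-out higher numbers stand for weaker inhibition and lower numbers for stronger inhibition. Compound 1 `COc1cc2c(Oc3ccc(NC(=O)N/N=C/c4ccc(C(F)(F)F)cc4)cc3F)ccnc2cc1OCCCN1CCCCC1` gives 660 nM. Going by the values given here, compound 2 `COc1cc2c(Oc3ccc(NC(=O)N/N=C/c4ccc(F)cc4Cl)cc3F)ccnc2cc1OCCCN1CCCCC1` gives 260 nM, the lowest of the two; the only step recorded, a 2.5-fold lower number from compound 1 to compound 2 (0.40 log units; beyond the scatter), is a change of the aryl group on the carbon with a double bond to nitrogen. Compound 3 `COc1cc2c(Oc3ccc(NC(=O)N/N=C/c4ccc(F)cc4Cl)cc3F)ccnc2cc1OCCCN1CCC(C)CC1` keeps the 2-chloro-4-fluorophenyl of compound 2 and differs from it only in methyl in place of hydrogen on a saturated ring carbon, so that piperidin-1-yl becomes 4-methylpiperidin-1-yl. Among the compounds with values here, no measured step touches this ring; the step from compound 1 to compound 2 therefore does not bear on it and gives no guide to direction or size. With nothing to set against the change, the expectation for compound 3 is a step of no change at the digits printed from compound 2 to compound 3 (within the scatter), within the scatter. The estimate for compound 3 in this assay is 260 nM, with a range from 100 nM to 700 nM.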

Compound 3, half-maximal inhibitory concentration: 440 nM
Compound 3: the middle estimate sits 1.7-fold (0.23 log units) below what was measured; the range from low to high includes it.
By their numbers in this assay, from the lowest: compounds 2, 3 and 1 (each within the scatter of the next, the first and the last beyond it).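

In this assay, going by these compounds alone, the methyl in place of hydrogen on a saturated ring carbon, three ring bonds from the ring nitrogen, gives a 1.7-fold higher number from compound 2 to compound 3 (0.23 log units; within the scatter) and is the first reading at this ring, since the earlier step touched only the aryl group. The piperidin-1-yl ring therefore accepts a methyl at this place without a step beyond the scatter, at least with the 2-chloro-4-fluorophenyl group of compound 2 in place. No supporting measurement is available to explain this reading.

As far as these compounds go, whether a larger or heteroatom-bearing group at this ring carbon, such as a hydroxyl, a dimethylamino group or a longer alkyl chain, would stay within the scatter remains open. Also open, from the compounds shown here alone, is whether 4-methylpiperidin-1-yl reads the same alongside the 4-(trifluoromethyl)phenyl group of compound 1.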